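Halogen swap on the benzothiazole of the flavone series

The compounds below may be only part of what the source reports. "The series", "measured", "known", "first", "only" and "open" are said of these compounds alone.

Compound 1 `O=c1cc(-c2ccccc2)oc2cc(OCCCCNc3nc4ccc([N+](=O)[O-])cc4s3)cc(O)c12` and compound 2 `O=c1cc(-c2ccccc2)oc2cc(OCCCCNc3nc4ccc(Cl)cc4s3)cc(O)c12` share one core and differ only at the benzothiazole, where compound 2 carries chloro in place of nitro. Among the compounds with values here, in a physicochemical assay, read by spectrophotometry, with a stated time of 10 min (on this read-out higher numbers stand for weaker inhibition and lower numbers for stronger inhibition), compound 1 gives 8.14 ug/mL, and compound 2 gives 4.16 ug/mL, the smaller of the two numbers measured so far, though the gap to compound 1 is within the scatter: a 2.0-fold lower number from compound 1 to compound 2 (0.29 log units; within the scatter).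

Compound 3 `O=c1cc(-c2ccccc2)oc2cc(OCCCCNc3nc4ccc(Br)cc4s3)cc(O)c12` continues the same exchange by one step: bromo in place of chloro on an aromatic carbon. Within the data shown here, only one measured step bears on this, the nitro-to-chloro move from compound 1 to compound 2, which itself stayed within the scatter. A bromo for chloro exchange at the same aromatic carbon is a smaller change than that one, so the expectation in this assay is for no step beyond the scatter, in either direction. The expected step of a 1.0-fold higher number from compound 2 to compound 3 (0.00 log units; within the scatter) is therefore essentially flat, with the range of a repeat measurement around it.

Compound 3 is estimated at 4.2 ug/mL, with a range from 2.1 ug/mL to 8.4 ug/mL.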

Compound 3, half-maximal inhibitory concentration: 6.57 ug/mL
Beside the measured number, compound 3's estimate is 1.6-fold (0.19 log units) below it; measured number inside the range.
By their numbers in this assay, from the lowest: compounds 2, 3 and 1 (each within the scatter of the next).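

In this assay, the step for bromo in place of chloro on this aromatic carbon of the 6-bromo-1,3-benzothiazol-2-yl group is a 1.6-fold higher number from compound 2 to compound 3 (0.20 log units; within the scatter), so a second halogen can now be compared with the first, and the two cannot be told apart on this read-out. The step for bromo in place of nitro is a 1.2-fold lower number from compound 1 to compound 3 (0.09 log units; within the scatter), which completes the set: nitro, chloro and bromo at this one carbon all lie within the scatter of one another, and compounds 1, 2 and 3 cannot be ranked. No measurement of any property of these groups is available that bears on this flat result.

Still open, going by these compounds, is whether an amine, a carboxylic acid or a methoxy group on this aromatic carbon would give a step beyond the scatter, or whether this carbon reads flat for groups of other kinds as well. Also open, on these data alone, is whether a longer chain in the linker of the shared core would shift the numbers, and whether nitro, chloro and bromo would still read alike on such a chain.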